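A few compounds are considered here, and "the series" means these few. Any claim that something is new, unique, unknown or untested is made for them only; others in the source may bear on it.

Measured compounds and their values in an ADME assay on MDCK cells (Canis lupus familiaris) for cytotoxicity, read by microscopy, with a stated time of 6 days; a higher number here means that more compound is tolerated, a lower number that less compound is tolerated:
compound 1 `CCCCCCNc1cncc(C(=O)NCc2ccccc2)n1` gives 20000 nM;
compound 2 `CCCCNc1cncc(C(=O)NCc2ccccc2)n1` gives 100000 nM;
compound 3 `CCCCCCCNc1cncc(C(=O)NCc2ccccc2)n1` gives 4000 nM.

The three share one core and differ only in the length of the chain on the aromatic nitrogen. From compound 1 to compound 2 the change is hydrogen in place of ethyl on a saturated chain carbon, four bonds along the chain from a nitrogen on an aromatic ring, and it made the step of a 5.0-fold higher number from compound 1 to compound 2 (0.70 log units; beyond the scatter). Compound 4 `CCCCCNc1cncc(C(=O)NCc2ccccc2)n1` is made from compound 3 by hydrogen in place of ethyl on a saturated chain carbon, five bonds along the chain from a nitrogen on an aromatic ring. This is the same kind of change, but the place differs: in compound 3 it sits five bonds along the chain from the nitrogen rather than four. The cores themselves differ by methyl in place of hydrogen on a saturated chain carbon, six bonds along the chain from a nitrogen on an aromatic ring, which made the step of a 5.0-fold lower number from compound 1 to compound 3 (0.70 log units; beyond the scatter).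

For compound 4 the chain length lies between those of compound 2 and compound 1. Compound 2 gives 100000 nM and compound 1 gives 20000 nM, so the number for compound 4 is expected to fall between these two. The expected step of an 11-fold higher number from compound 3 to compound 4 (1.05 log units; beyond the scatter) is therefore estimated somewhat larger than the earlier one. Compound 4 is estimated at 45000 nM, between 20000 nM and 100000 nM.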

Compound 4, minimum cytotoxic concentration: 20000 nM
Compound 4: the middle estimate sits 2.3-fold (0.35 log units) above what was measured; the range from low to high includes it.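

In this assay, hydrogen in place of ethyl on the chain gave a matching step on two cores, with a 5.0-fold higher number from compound 3 to compound 4 (0.70 log units; beyond the scatter) repeating the earlier result: the same change on two cores in this assay, a 5.0-fold higher number (0.70 log units; beyond the scatter) from compound 1 to compound 2 and a 5.0-fold higher number (0.70 log units; beyond the scatter) from compound 3 to compound 4, 1.0-fold (0.00 log units) apart, within the scatter of two such steps

Methyl in place of hydrogen also carried over, with a 5.0-fold lower number from compound 2 to compound 4 (0.70 log units; beyond the scatter) repeating its earlier step: the same change on two cores in this assay, a 5.0-fold lower number (0.70 log units; beyond the scatter) from compound 1 to compound 3 and a 5.0-fold lower number (0.70 log units; beyond the scatter) from compound 2 to compound 4, 1.0-fold (0.00 log units) apart, within the scatter of two such steps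

This holds only for these four simple chains and does not show an even trend with chain length, as the pentyl chain of compound 4 and the hexyl chain of compound 1 show no change at the digits printed from compound 1 to compound 4 (within the scatter).

Still open, from the compounds shown here alone, is whether a longer chain than the heptyl of compound 3 would follow the same steps. Equally open, going by these compounds, is how a chain ending in an amine or a carboxylic acid would behave.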